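The compounds below may be only part of what the source reports. "The series", "measured", "known", "first", "only" and "open" are said of these compounds alone.

Compound 1 `O=C(/C=C/c1cccc(OCc2ccccc2)c1)c1ccc([N+](=O)[O-])cc1` stands highest of the three measured numbers in a functional assay on A2780 cells (Homo sapiens) for cytotoxicity, read by MTT assay, with a stated time of 68 h (on this read-out lower numbers stand for stronger inhibition and higher numbers for weaker inhibition), where compound 1 gives 56400 nM. Its nearest neighbour is compound 3 `O=C(/C=C/c1cccc(OCc2ccccc2)c1)c1ccc(Br)cc1`, which gives 1800 nM, and the furthest is compound 2 `O=C(/C=C/c1cccc(OCc2ccccc2)c1)c1ccc(O)cc1`, which gives 1000 nM. Both changes at the same aromatic carbon moved the number by a large margin: a 56-fold lower number from compound 1 to compound 2 (1.75 log units; beyond the scatter) and a 31-fold lower number from compound 1 to compound 3 (1.50 log units; beyond the scatter), while a 1.8-fold higher number from compound 2 to compound 3 (0.26 log units; within the scatter) leaves compound 2 and compound 3 within the scatter of each other.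

Compound 4 `O=C(/C=C/c1cccc(OCc2ccccc2)c1)c1cccc(Br)c1` differs from compound 1 by 3-bromophenyl in place of 4-nitrophenyl on a carbonyl carbon. The step that bears on it most is the exchange of nitro for bromo, a 31-fold lower number from compound 1 to compound 3 (1.50 log units; beyond the scatter), although the bromine in compound 4 sits on a different carbon of the ring than in compound 3, so the carry-over is not exact. It is therefore expected that the number falls by a large step, a 23-fold lower number from compound 1 to compound 4 (1.35 log units; beyond the scatter), in the direction of stronger inhibition. Compound 4 is estimated at 2500 nM, with a range from 700 nM to 9000 nM.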

Compound 4, half-maximal inhibitory concentration: 6300 nM
Compound 4: middle estimate off by 2.5-fold (0.40 log units), on the low side; the range from low to high includes it.
By their numbers in this assay, from the lowest: compounds 2 and 3 (each within the scatter of the next); then compound 4; then compound 1.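

In this assay, the place of the bromine on the ring at the carbonyl carbon matters in its own right, with a 3.5-fold higher number from compound 3 to compound 4 (0.54 log units; beyond the scatter) for 3-bromophenyl in place of 4-bromophenyl. The exchange of 4-nitrophenyl for 3-bromophenyl still gives a 9.0-fold lower number from compound 1 to compound 4 (0.95 log units; beyond the scatter) and so keeps part of the gain seen with 4-bromophenyl, but only part. Where 4-hydroxyphenyl and 4-bromophenyl lie within the scatter of each other, 3-bromophenyl stands apart from the former, with a 6.3-fold higher number from compound 2 to compound 4 (0.80 log units; beyond the scatter) for the exchange.

Nothing available here accounts for this effect of the bromine's place. The compounds shown leave open whether hydroxy or nitro would respond to the same change of ring carbon as bromo did, and how an amine or a carboxylic acid on this ring would stand.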